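Fluoro to Nitro on Two Lactone Cores

A few compounds are considered here, and "the series" means these few. Any claim that something is new, unique, unknown or untested is made for them only; others in the source may bear on it.

Measured compounds:
Compound 1, `O=C1C=C[C@@H](OCc2ccccc2)[C@@H]([C@@H](COC(=O)/C=C/c2ccc(F)cc2)OCc2ccccc2)O1`, gives 5400 nM in a functional assay on HL-60 cells (Homo sapiens) for antiproliferative activity, read by MTT assay, with a stated time of 6 days; on this read-out lower numbers stand for stronger inhibition and higher numbers for weaker inhibition.
Compound 2, `O=C1C=C[C@@H](OCc2ccccc2)[C@@H]([C@@H](COC(=O)/C=C/c2ccc([N+](=O)[O-])cc2)OCc2ccccc2)O1`, gives 2530 nM in this assay.
Compound 3, `CC(=O)O[C@@H]1C=CC(=O)O[C@@H]1[C@@H](COC(=O)/C=C/c1ccc(F)cc1)OC(C)=O`, gives 1890 nM in this assay.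

Compound 1 and compound 2 share one core and differ only in nitro in place of fluoro on an aromatic carbon; that change produced a 2.1-fold lower number from compound 1 to compound 2 (0.33 log units; beyond the scatter). Compound 3 carries a different core, and the difference between the two cores is not broken down here. Compound 4, `CC(=O)O[C@@H]1C=CC(=O)O[C@@H]1[C@@H](COC(=O)/C=C/c1ccc([N+](=O)[O-])cc1)OC(C)=O`, has not yet been measured; it stands to compound 3 as compound 2 stands to compound 1, the change being (nitro in place of fluoro on an aromatic carbon). Because the same change gave a 2.1-fold lower number from compound 1 to compound 2 (0.33 log units; beyond the scatter), a step of similar size is expected from compound 3 to compound 4, namely a 2.1-fold lower number from compound 3 to compound 4 (0.32 log units; beyond the scatter). Compound 4 is therefore estimated at 900 nM in this assay, expected to lie between 450 nM and 2000 nM.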

Compound 4, half-maximal inhibitory concentration: 4030 nM
Estimate against measurement, compound 4: 4.5-fold (0.65 log units) below; measured number outside the range, above it.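

In this assay nitro in place of fluoro gave a 2.1-fold higher number from compound 3 to compound 4 (0.33 log units; beyond the scatter) and so moved the number the opposite way from the step on the core of compound 1: the same change on two cores in this assay, a 2.1-fold lower number (0.33 log units; beyond the scatter) from compound 1 to compound 2 and a 2.1-fold higher number (0.33 log units; beyond the scatter) from compound 3 to compound 4, 4.6-fold (0.66 log units) apart, beyond the scatter of two such steps. In these two pairs, then, the outcome of the change depends on the core, and a step read on one core cannot simply be carried over to the other. Two pairs do not show which part of the cores is responsible, nor how the change would behave on any further core.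

Only fluoro and nitro appear on the aromatic carbon in question. An amine or a chlorine there could show whether other groups also part ways between the two cores.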